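Swapping dichlorophenyl for acetylphenyl on the benzamide urea

The compounds below may be only part of what the source reports. "The series", "measured", "known", "first", "only" and "open" are said of these compounds alone.

Compound 3 `Cc1ccc(NC(=O)Nc2ccc(Cl)c(Cl)c2)cc1NC(=O)c1ccccc1` was tested in a functional assay on A375P cells (Homo sapiens) for antiproliferative activity (a higher number here means a weaker inhibitor, a lower number a stronger inhibitor), where compound 3 gives 5800 nM. Among the three compounds measured so far it stands second highest: its nearest neighbour is compound 1 `CC(=O)Nc1cc(NC(=O)Nc2ccc(Cl)c(Cl)c2)ccc1C`, for which compound 1 gives 2100 nM, and the step of a 2.8-fold higher number from compound 1 to compound 3 (0.44 log units; beyond the scatter) is described as phenyl in place of methyl on a carbonyl carbon. The furthest value belongs to compound 2 `CC(=O)Nc1cc(NC(=O)Nc2cccc(C(C)=O)c2)ccc1C`, where compound 2 gives 22100 nM.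

Compound 4 `CC(=O)c1cccc(NC(=O)Nc2ccc(C)c(NC(=O)c3ccccc3)c2)c1` has not yet been measured. It differs from compound 3 by 3-acetylphenyl in place of 3,4-dichlorophenyl on an amide-type nitrogen. Among the compounds with values here, no step of exactly this kind has been quantified on the benzamide core, but compound 1 and compound 2 carry the same pair of aryl groups on the acetamide core, and there the value rises sharply from the dichlorophenyl compound 1 to the acetylphenyl compound 2. By analogy, compound 4 is expected to give a clearly higher number, estimated as a 9.5-fold higher number from compound 3 to compound 4 (0.98 log units; beyond the scatter), so that compound 4 is estimated at 55000 nM, within a range from 15000 nM to 200000 nM.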

Compound 4, half-maximal inhibitory concentration: 9800 nM
Estimate against measurement, compound 4: 5.6-fold (0.75 log units) above; measured number outside the range, below it.
By their numbers in this assay, from the lowest: compound 1; then compounds 3 and 4 (each within the scatter of the next); then compound 2.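

In this assay, exchanging 3,4-dichlorophenyl for 3-acetylphenyl on the amide-type nitrogen makes no readable difference when phenyl sits on the carbonyl carbon, the step being a 1.7-fold higher number from compound 3 to compound 4 (0.23 log units; within the scatter), whereas with methyl there compound 1 gives 2100 nM and compound 2 gives 22100 nM. The change of methyl to phenyl on the carbonyl carbon, which earlier came with a higher number, now runs the other way, with a 2.3-fold lower number from compound 2 to compound 4 (0.35 log units; beyond the scatter). The outcome of this change therefore depends on the aryl group carried on the amide-type nitrogen, and its direction reverses: the same change on two cores in this assay, a 2.8-fold higher number (0.44 log units; beyond the scatter) from compound 1 to compound 3 and a 2.3-fold lower number (0.35 log units; beyond the scatter) from compound 2 to compound 4, 6.2-fold (0.79 log units) apart, beyond the scatter of two such steps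

Only two aryl groups and two carbonyl substituents are shown, so the generality of this reversal remains open. On these data alone, it is unknown how a 3-aminophenyl group on that nitrogen, or a longer alkyl chain on the carbonyl carbon, would behave.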